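Working notes: amide terminus change from compound 2 to compound 3

A few compounds are considered here, and "the series" means these few. Any claim that something is new, unique, unknown or untested is made for them only; others in the source may bear on it.

Measured so far in an assay on isolated protein for inhibition of glutathione S-transferase Mu 2 (Homo sapiens), with a stated time of 10 min; a lower number here means a stronger inhibitor, a higher number a weaker inhibitor:
Compound 1, `O=C(CCC(=O)OCCCCCCSc1ccc([N+](=O)[O-])c2nonc12)Nc1ccccc1F`: compound 1 gives 350 nM.
Compound 2, `O=C(CCC(=O)OCCCCCCSc1ccc([N+](=O)[O-])c2nonc12)Nc1ccc(F)cc1`: compound 2 gives 320 nM.

Among the compounds with values here, compound 2 holds the lowest of the two numbers, but its only neighbour is compound 1 and the step of a 1.1-fold lower number from compound 1 to compound 2 (0.04 log units; within the scatter) lies within the scatter, so the two cannot be placed in order.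

Compound 3, `O=C(CCC(=O)N1CCOCC1)OCCCCCCSc1ccc([N+](=O)[O-])c2nonc12`, is not yet measured. It differs from compound 2 on a carbonyl carbon whose other neighbour is a saturated chain carbon: morpholin-4-yl in place of (4-fluorophenyl)amino on a carbonyl carbon. Within the data shown here, the single measured step puts 4-fluorophenyl in place of 2-fluorophenyl on an amide-type nitrogen and keeps the amide hydrogen and the aromatic ring; it gives no guidance on exchanging (4-fluorophenyl)amino for morpholin-4-yl. Among the measured compounds shown here, no measured step therefore bears on this change, and the direction of its effect in this assay is open. With no supporting data, a modest weakening is taken as the working expectation. Compound 3 is expected to give 550 nM, in a range of 200 nM to 1600 nM. This corresponds to an expected step of a 1.7-fold higher number from compound 2 to compound 3 (0.24 log units; within the scatter).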

Compound 3, half-maximal inhibitory concentration: 170 nM
Compound 3: the middle estimate sits 3.2-fold (0.51 log units) above what was measured, outside the stated range (below it).
By their numbers in this assay, from the lowest: compounds 3, 2 and 1 (each within the scatter of the next, the first and the last beyond it).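

Working notes, after compound 3. In this assay, the carbonyl carbon whose other neighbour is a saturated chain carbon is now shown to accept a terminus with neither the amide hydrogen nor an aromatic ring, and the number stays in the same range. Against (4-fluorophenyl)amino, morpholin-4-yl cannot be told apart (a 1.9-fold lower number from compound 2 to compound 3 (0.27 log units; within the scatter)), while against (2-fluorophenyl)amino it gives the only step in the series so far that clears the scatter (a 2.1-fold lower number from compound 1 to compound 3 (0.31 log units; beyond the scatter)), though that step is modest and compounds 1 and 2 themselves cannot be ordered. No measurement on these compounds accounts for this result.

The amide hydrogen, the aromatic ring and the ring oxygen of morpholin-4-yl all change together in these steps, so the compounds shown do not say which of them, if any, governs the number. Piperidin-1-yl or dimethylamino on the same carbonyl carbon would start to separate these features, and whether the morpholin-4-yl result holds with a longer chain in the ester part remains open.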